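The source may report more compounds than this note shows. Statements on the series, on what has been measured and on what is new or still open speak of the compounds shown alone.

Measured compounds in a functional assay on HeLa cells (Homo sapiens) for inhibition, read by sulforhodamine B assay; on this read-out higher numbers stand for weaker inhibition and lower numbers for stronger inhibition:
compound 1 `O=C1C=C(Nc2ccc(I)cc2)C(=O)c2c1nc1n2[C@H]2OC[C@@H](O)[C@H]2OC1`; compound 1 gives 4070 nM.
compound 2 `CCc1ccc(NC2=CC(=O)c3nc4n(c3C2=O)[C@H]2OC[C@@H](O)[C@H]2OC4)cc1`; compound 2 gives 3990 nM.
compound 3 `O=C1C=C(NC2CCCC2)C(=O)c2c1nc1n2[C@H]2OC[C@@H](O)[C@H]2OC1`; compound 3 gives only a limit of the assay, > 16000 nM.

Compound 3 thus stands at the weak end of the numbers shown: it reaches only the limit, (the limit of > 16000 nM in this assay, at which 1 of the 3 values shown sits), and no number. Compound 4 `CCOc1ccc(NC2=CC(=O)c3nc4n(c3C2=O)[C@H]2OC[C@@H](O)[C@H]2OC4)cc1` differs from it as follows: 4-ethoxyphenyl in place of cyclopentyl on an amine nitrogen. The measured steps that bear on this change are the two moves from 4-iodophenyl and from 4-ethylphenyl to cyclopentyl on the same nitrogen, an at least 3.9-fold higher number from compound 1 to compound 3 (0.59 log units; beyond the scatter) and an at least 4.0-fold higher number from compound 2 to compound 3 (0.60 log units; beyond the scatter). The present change runs the other way, from cyclopentyl back to a substituted phenyl ring of the kind carried by compound 1 and compound 2, so a step toward lower numbers in this assay, at least as large as those two, is expected for compound 4. Among the compounds with values here, the ethoxy group itself has no counterpart among the measured compounds, so its own contribution is unknown. Compound 4 is therefore estimated at about 4500 nM, within 1500 nM to 14000 nM. The expected step is an at least 3.5-fold lower number from compound 3 to compound 4 (0.55 log units; beyond the scatter).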

Compound 4, half-maximal inhibitory concentration: 3110 nM
Compound 4: middle estimate off by 1.4-fold (0.16 log units), on the high side, within the range that was stated.
By their numbers in this assay, from the lowest: compounds 4, 2 and 1 (each within the scatter of the next). At a limit, above all of these: compound 3.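

In this assay, 4-ethoxyphenyl on the amine nitrogen gives an at least 5.1-fold lower number from compound 3 to compound 4 (0.71 log units; beyond the scatter), so all three substituted phenyl groups shown now sit apart from cyclopentyl, and no compound shown goes against this. Compound 3 remains a limit of the assay and not a number: the limit of > 16000 nM in this assay, at which 1 of the 4 values shown sits.
The group on the phenyl ring makes no readable difference among the three shown: ethoxy in place of ethyl gives a 1.3-fold lower number from compound 2 to compound 4 (0.11 log units; within the scatter), and ethoxy in place of iodo gives a 1.3-fold lower number from compound 1 to compound 4 (0.12 log units; within the scatter).

Open, going by these compounds, is whether an amine or a carboxylic acid on the phenyl ring would stay level with compound 1, compound 2 and compound 4. Also open, on these data alone, is whether an unsubstituted phenyl or a longer chain on the amine nitrogen would sit with those compounds or with compound 3.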